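Trifluoromethyl for chloro on the aryl ring of compound 2

A few compounds are considered here, and "the series" means these few. Any claim that something is new, unique, unknown or untested is made for them only; others in the source may bear on it.

Of the compounds shown here, three share a core and have been tested in an assay on cells for displacement of a labelled ligand from adenosine receptor A2b (Homo sapiens), read by scintillation counting and radioligand binding, with a stated time of 30 min, tested at 10 uM; a higher number here means more inhibition at the concentration tested (going by the name of the read-out), a lower number less inhibition. Compound 1 `CN1CCN(c2nc(-c3ccc(Cl)cc3)nc3[nH]cnc23)CC1` gives 6.2%. Compound 2 `CN1CCN(c2nc(-c3ccc(Cl)c(Cl)c3)nc3[nH]cnc23)CC1` gives 24.1%, the second highest of the three numbers; compound 3 `CN1CCN(c2nc(-c3ccccc3O)nc3c2ncn3C)CC1` gives 36%, the step from compound 2 to compound 3 lying beyond the scatter. Going by the values given here, the only measured step is a number 17.9 percentage points higher from compound 1 to compound 2 (beyond the scatter), which shows that adding a group on that aromatic carbon raised inhibition by a modest amount.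

Compound 4 `CN1CCN(c2nc(-c3ccc(Cl)c(C(F)(F)F)c3)nc3[nH]cnc23)CC1` differs from compound 2 in one place: trifluoromethyl in place of chloro on an aromatic carbon. Among the compounds with values here, no measured step exchanges one group for another at this position, so the step to compound 4 has no direct precedent; the step from compound 1 to compound 2 shows only that the number with a group there is higher than without one. The account therefore expects a step of about a number 3.9 percentage points higher from compound 2 to compound 4 (within the scatter), within the scatter, with no clear direction. Compound 4 is estimated to give 28% in this assay, expected between 10% and 50%.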

Compound 4, a percentage reported as inhibition, at one concentration (the size of the read-out at that concentration, not a potency): 25.1%
For compound 4 the middle estimate is 2.9 percentage points above the measured one, and the stated range covers the measured number.
By their numbers in this assay, from the lowest: compound 1; then compounds 2 and 4 (each within the scatter of the next); then compound 3.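

In this assay, the exchange of chloro for trifluoromethyl on this aromatic carbon gives a number 1 percentage points higher from compound 2 to compound 4 (within the scatter), so a group of four heavy atoms and one of a single heavy atom cannot be told apart here. Set against hydrogen at the same carbon, trifluoromethyl gives a number 18.9 percentage points higher from compound 1 to compound 4 (beyond the scatter), so the rise seen with chloro is not confined to that one group. No measurement offered here bears on why the two groups read alike.

From the compounds shown here alone, it remains open whether a group of another kind on this carbon, such as an amine or a carboxylic acid, would keep this number or lose it. Going by these compounds, with a read-out taken at one concentration, it is also open whether compound 2 and compound 4 would still read alike as potencies.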